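The compounds below may be only part of what the source reports. "The series", "measured", "known", "first", "only" and "open" are said of these compounds alone.

Working notes on the series.

Three compounds carry numbers in a functional assay on SW1573 cells (Homo sapiens) for antiproliferative activity, read by sulforhodamine B assay, with a stated time of 48 h; a higher number here means a weaker inhibitor of growth, a lower number a stronger inhibitor of growth. Compound 1, `CC1CCC(C(C)C)C(OC(=O)C#CC(O/C=C/C(=O)OC2CC(C)CCC2C(C)C)C(C)C)C1`, gives only a limit, > 100000 nM, and no number; this is the boundary described by the limit of > 100000 nM in this assay, at which 1 of the 3 values shown sits. Compound 2, `COC(=O)C#CC(C[C@@H](C)CCC=C(C)C)O/C=C/C(=O)OC`, gives 2200 nM in this assay. Compound 3, `COC(=O)C#CC(O/C=C/C(=O)OC)C1CCCCC1`, gives 2100 nM in this assay. Among the two numbers that are actual values, compound 3 carries the lower one, but its gap to compound 2 lies within the scatter, so the two cannot be told apart and neither is called the stronger inhibitor of growth.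

The next compound, compound 4, `COC(=O)C#CC(C)O/C=C/C(=O)OC`, has not yet been measured in this assay. It differs from compound 3 in one place: methyl in place of cyclohexyl on a saturated chain carbon bound to an oxygen on an unsaturated carbon and a triple-bonded carbon. For the measured compounds named here, no measured step of this kind exists, so the size of the change can only be expected, not read off.

The expectation is that the step from compound 3 to compound 4, a 2.9-fold higher number from compound 3 to compound 4 (0.46 log units; beyond the scatter), leads to a somewhat higher number, beyond the scatter but not by a large margin. On that basis compound 4 is estimated at 6000 nM in this assay, with a range from 2000 nM to 25000 nM.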

Compound 4, concentration for 50% growth inhibition: 1700 nM
For compound 4 the middle estimate is 3.5-fold (0.55 log units) above the measured one; measured number outside the range, below it.
By their numbers in this assay, from the lowest: compounds 4, 3 and 2 (each within the scatter of the next). At a limit, above all of these: compound 1.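

At the position named in the step, on a saturated chain carbon bound to an oxygen on an unsaturated carbon and a triple-bonded carbon, the series now has its first measured change, methyl in place of cyclohexyl, and it reads a 1.2-fold lower number from compound 3 to compound 4 (0.09 log units; within the scatter) in this assay. Compounds 2 and 3 alone could not show this, as they differ from each other in more than one place: the pair of compound 3 and compound 4 shows that the six-membered ring at this position can give way to methyl with no change that can be told from the scatter, so the ring is not required for a number of this order in this series. Nothing measured here bears on why the number holds across this change.

For the compounds shown here, compound 1 gives > 100000 nM, which is a limit and not a number, and it differs from the other compounds in more than one place, so no step to it can be read. Still open, on these data alone, is whether an amine, a carboxylic acid or a phenyl ring at this same position would keep the number at this level, and what hydrogen in place of methyl would do.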